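Bromo on the Fused Core of a Sulfonylurea Series

A few compounds are considered here, and "the series" means these few. Any claim that something is new, unique, unknown or untested is made for them only; others in the source may bear on it.

Measured compounds and their read-outs:
compound 1, `O=C(NS(=O)(=O)c1ccccc1)n1ccc2cccnc21`, 19%
compound 2, `O=C(NS(=O)(=O)c1cccc([N+](=O)[O-])c1)n1ccc2cccnc21`, 70.7%
compound 3, `Cc1ccc(S(=O)(=O)NC(=O)n2ccc3cccnc32)cc1`, 20.3%

In a functional assay on MCF7 cells (Homo sapiens) for antiproliferative activity, read by MTT assay, with a stated time of 24 h, tested at 10 uM (a higher number here means more inhibition at the concentration tested (going by the name of the read-out), a lower number less inhibition), compound 1 gives 19%, the lowest of the three numbers. Compound 3 sits closest, a number 1.3 percentage points higher from compound 1 to compound 3 (within the scatter), which is within the scatter, while compound 2 stands furthest away, a number 51.7 percentage points higher from compound 1 to compound 2 (beyond the scatter), a large step beyond the scatter.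

Compound 4, `O=C(NS(=O)(=O)c1ccccc1)n1ccc2cc(Br)cnc21`, has not yet been measured. Compared with compound 1 the change is bromo in place of hydrogen on an aromatic carbon. Neither measured step bears directly on it: both changes from compound 1 to compounds 2 and 3 sit on a different part of the molecule than the fused ring system, and neither introduces a bromine. The step of a number 51.7 percentage points higher from compound 1 to compound 2 (beyond the scatter) shows that a single substituent can move this read-out a long way, whereas a number 1.3 percentage points higher from compound 1 to compound 3 (within the scatter) shows that another single substituent leaves it unchanged. For the measured compounds named here, with no closer precedent, the step to compound 4 is expected to be modest and, if anything, upward.

Compound 4 is therefore estimated at 28%, between 12% and 50%. This estimate means an expected a number 9 percentage points higher from compound 1 to compound 4 (within the scatter), a step that may well stay within the scatter.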

Compound 4, a percentage reported as inhibition, at one concentration (the size of the read-out at that concentration, not a potency): 16.8%
Estimate against measurement, compound 4: 11.2 percentage points above; low and high end bracket the measured number.
By their numbers in this assay, from the lowest: compounds 4, 1 and 3 (each within the scatter of the next); then compound 2.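

In this assay, bromo in place of hydrogen on an aromatic carbon of the six-membered aromatic ring with 1 nitrogen, two atoms from the ring nitrogen, gives a number 2.2 percentage points lower from compound 1 to compound 4 (within the scatter). This is the first step shown on the fused ring system: the earlier steps, a number 51.7 percentage points higher from compound 1 to compound 2 (beyond the scatter) and a number 1.3 percentage points higher from compound 1 to compound 3 (within the scatter), both lay on a different part of the molecule, so they said nothing about this carbon, and here a single bromine leaves the read-out within the scatter of compound 1. Nothing among the data presented accounts for this result, and no measurement offers an explanation for it.

Going by these compounds, what an amine, a carboxylic acid or a longer chain would do on this same carbon stays open, as a single bromine speaks only for itself and cannot show whether this position is insensitive to other groups. Also open, on these data alone, is whether the nitro group of compound 2, which gives 70.7%, would keep that number with bromo on the fused ring system as well.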